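The source may hold more compounds than are shown below. What is called first, only, known or untested is meant among the compounds shown, and "the series" means these compounds.

Compound 1 `O=C(CN1CCN(c2ccccc2)CC1)N1CCN(c2nnc(-c3ccc(Cl)cc3)c(-c3ccc(Cl)cc3)n2)CC1`: > 850000 nM
Compound 2 `COc1cccc(N2CCN(CC(=O)N3CCN(c4nnc(-c5ccc(Cl)cc5)c(-c5ccc(Cl)cc5)n4)CC3)CC2)c1`: 202000 nM

In an ADME assay on NIH3T3 cells (Mus musculus) for cytotoxicity, read by MTT assay, with a stated time of 24 h (a lower number here means a stronger inhibitor, a higher number a weaker inhibitor), compound 1 gives > 850000 nM, which is a limit of the assay rather than a number. In this assay, among the measured compounds shown here, compound 2 gives 202000 nM, the only plain number in the set. The step seen so far is an at least 4.2-fold lower number from compound 1 to compound 2 (0.62 log units; beyond the scatter), starting from the limit of > 850000 nM in this assay, at which 1 of the 2 values shown sits. Compound 3 `O=C(CN1CCN(c2cccc(Cl)c2)CC1)N1CCN(c2nnc(-c3ccc(Cl)cc3)c(-c3ccc(Cl)cc3)n2)CC1` differs from compound 2 by chloro in place of methoxy on an aromatic carbon. For the measured compounds named here, no measured step exchanges these two groups, so the single known step is only a weak guide, and no change beyond the scatter is expected in this assay. Compound 3 is estimated at 250000 nM, between 80000 nM and 800000 nM. The expected step is a 1.2-fold higher number from compound 2 to compound 3 (0.09 log units; within the scatter).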

Compound 3, half-maximal inhibitory concentration: > 803000 nM
Compound 3 was reported as a limit; the forecaster's own chance of this, stated with the estimate: 30%; middle value at least 3.2-fold (0.50 log units) from the limit.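

In this assay, chloro in place of methoxy gives an at least 3.9-fold higher number from compound 2 to compound 3 (0.59 log units; beyond the scatter), so at this place on the ring, the lower number of compound 2 does not appear with just any group that replaces hydrogen. Compound 3 stands at a limit of the assay, not a plain number: the limit of > 803000 nM in this assay, at which 1 of the 3 values shown sits. The step between compound 1 and compound 3 cannot be read.

From the compounds shown here alone, whether the lower number is tied to methoxy itself stays open. An amine or a longer chain such as ethoxy at this place would help to tell.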